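Methyl-to-hydrogen step on the four-membered ring, second pair

A few compounds are considered here, and "the series" means these few. Any claim that something is new, unique, unknown or untested is made for them only; others in the source may bear on it.

Measured so far:
Compound 1 `O[C@H](c1ccccn1)[C@]1(c2ccc(C(F)(F)F)cc2)C[C@@H](O)C1`: 1870 nM
Compound 2 `C[C@]1(O)C[C@@](c2ccc(C(F)(F)F)cc2)([C@H](O)c2ccccn2)C1`: 840 nM
Compound 3 `C[C@]1(O)C[C@@](c2cc(C(F)(F)F)ccn2)([C@H](O)c2ccccn2)C1`: 730 nM

In an assay on HEK293 cells for antagonist activity at transient receptor potential cation channel subfamily V member 3 (Homo sapiens), read by FLIPR and calcium flux (a higher number here means a weaker inhibitor, a lower number a stronger inhibitor), compound 2 gives 840 nM, compound 1 gives 1870 nM. The step of a 2.2-fold higher number from compound 2 to compound 1 (0.35 log units; beyond the scatter) comes from hydrogen in place of methyl on a saturated ring carbon. Compound 3 gives 730 nM; the difference between the core of compound 3 and the core of compound 2 is not broken down here.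

Compound 4 `O[C@H](c1ccccn1)[C@]1(c2cc(C(F)(F)F)ccn2)C[C@@H](O)C1` is not yet measured. It differs from compound 3 by hydrogen in place of methyl on a saturated ring carbon, the same change, at the same place, as that made from compound 2 to compound 1. For the measured compounds named here, with only one earlier pair to rest on, the expected step is a 2.2-fold higher number from compound 3 to compound 4 (0.34 log units; beyond the scatter), taken to be of the same size as a 2.2-fold higher number from compound 2 to compound 1 (0.35 log units; beyond the scatter). For compound 4 the expected number in this assay is 1600 nM, with a likely range from 850 nM to 3200 nM.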

Compound 4, antagonist equilibrium constant: 320 nM
Compound 4: the middle estimate sits 5.0-fold (0.70 log units) above what was measured; the whole stated range lies above it.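

In this assay, hydrogen in place of methyl on a saturated ring carbon gives a 2.3-fold lower number from compound 3 to compound 4 (0.36 log units; beyond the scatter), so in these two pairs the direction of the change depends on the core that carries it: the same change on two cores in this assay, a 2.2-fold higher number (0.35 log units; beyond the scatter) from compound 2 to compound 1 and a 2.3-fold lower number (0.36 log units; beyond the scatter) from compound 3 to compound 4, 5.1-fold (0.71 log units) apart, beyond the scatter of two such steps

For the compounds shown here, the comparison rests on only two pairs; it does not show which feature of the two cores accounts for the opposite steps, or how the change would behave on any further core. A step measured on one core therefore gives no reliable estimate for the other in this series.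

Going by these compounds, it remains open whether an ethyl group on this ring carbon would also give core-dependent steps. Also open, on these data alone, is how an amine in place of the hydroxy group on the same carbon would compare on each core.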